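Methyl Addition on a Fused Core: Expected Loss Again

The compounds below may be only part of what the source reports. "The series", "measured", "known", "first", "only" and "open" are said of these compounds alone.

Measured compounds:
- compound 1 `Cc1ccnc2nc(-c3cccc4ccccc34)cc(O)c12`, < 10 nM 
- compound 2 `Cc1cc(C)c2c(O)cc(-c3cccc4ccccc34)nc2n1`, 347 nM 
- compound 3 `Cc1ccc2c(O)cc(-c3ccc4ccccc4c3)nc2n1`, 3630 nM 

All three were tested in a functional assay on OVCAR-3 cells (Homo sapiens) for antiproliferative activity; on this read-out higher numbers stand for weaker inhibition of growth and lower numbers for stronger inhibition of growth. For compound 1 the value < 10 nM is a limit of the assay rather than a number, being (the limit of < 10 nM in this assay, at which 1 of the 3 values shown sits). Compound 2 differs from compound 1 by methyl in place of hydrogen on an aromatic carbon, and this gave an at least 34-fold higher number from compound 1 to compound 2 (1.54 log units; beyond the scatter). Compound 3 carries the same atoms as compound 1 joined differently; the difference between the two cores is not broken down here. In this assay compound 3 gives 3630 nM.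

Compound 4 `Cc1cc(C)c2c(O)cc(-c3ccc4ccccc4c3)nc2n1` has not been measured. It differs from compound 3 by methyl in place of hydrogen on an aromatic carbon, the same kind of change as from compound 1 to compound 2, though the surroundings differ: in compound 2 the methyl sits next to the ring nitrogen and para to a fused ring, while in compound 4 it sits ortho to a fused ring and opposite the ring nitrogen. Because the earlier step of an at least 34-fold higher number from compound 1 to compound 2 (1.54 log units; beyond the scatter) was large, a weakening is expected here too, giving an estimated 4.1-fold higher number from compound 3 to compound 4 (0.62 log units; beyond the scatter). Compound 4 is expected to give about 15000 nM, between 3000 nM and 60000 nM.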

Compound 4, concentration for 50% growth inhibition: 20000 nM
Compound 4: middle estimate off by 1.3-fold (0.12 log units), on the low side; the range from low to high includes it.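

Adding the methyl on an aromatic carbon raised the number again in this assay, giving a 5.5-fold higher number from compound 3 to compound 4 (0.74 log units; beyond the scatter), so the direction of the change held on both cores. The size of the step did not carry over, and these two cores alone cannot tell why, or what the same methyl would do on a further core: the same change on two cores in this assay, an at least 34-fold higher number (1.54 log units; beyond the scatter) from compound 1 to compound 2 and a 5.5-fold higher number (0.74 log units; beyond the scatter) from compound 3 to compound 4, at least 6.2-fold (0.79 log units) apart, beyond the scatter of two such steps. For compound 1 the value is a limit of the assay and not a number: the limit of < 10 nM in this assay, at which 1 of the 4 values shown sits.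

The compounds shown carry only hydrogen or methyl at this aromatic carbon, so the effect of an ethyl group, a methoxy group, a chlorine atom or an amine there remains open. Also open, on these data alone, is what would happen if the hydroxyl group, present in all four compounds, were replaced by an amine.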